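Benzhydryl and Thienylmethyl Sulfoxides at the Dopamine Transporter

The source may hold more compounds than are shown below. What is called first, only, known or untested is meant among the compounds shown, and "the series" means these compounds.

Measured compounds:
compound 1, `Cc1nc(O)cc(C[S+]([O-])C(c2ccccc2)c2ccccc2)n1`: 3100 nM
compound 2, `Cc1ccc(C(c2ccc(C)cc2)[S+]([O-])Cc2cccs2)cc1`: 5800 nM

Two sulfoxides have been measured in an assay on HEK293 cells for inhibition of sodium-dependent dopamine transporter (Homo sapiens), read by scintillation counting, with stated times of 5 min and 1 min; a higher number here means a weaker inhibitor, a lower number a stronger inhibitor. Compound 1 gives 3100 nM in this assay, the lower of the two numbers. Compound 2, in which the sulfur carries a thienylmethyl group and a carbon bearing two tolyl rings, gives 5800 nM; its gap to compound 1 lies within the usual scatter, so the two cannot be set apart on these data.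

Compound 3, `[O-][S+](Cc1ccc(Cl)s1)C(c1ccccc1)c1ccccc1`, has not yet been measured. It keeps the diphenylmethyl sulfoxide core of compound 1 and differs in one place: 5-chlorothiophen-2-yl in place of 6-hydroxy-2-methylpyrimidin-4-yl on a saturated chain carbon bound to a sulfur. The heteroaryl group on the chain carbon is thus exchanged for one resembling the thienyl of compound 2, while the phenyl rings of compound 1 are retained. Among the compounds with values here, with no step between measured compounds to lean on, the expected change from compound 1 to compound 3 is small, around a 1.0-fold lower number from compound 1 to compound 3 (0.01 log units; within the scatter), in neither direction beyond the scatter. Compound 3 is therefore expected to give about 3000 nM in this assay, with a range from 800 nM to 12000 nM.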

Compound 3, half-maximal inhibitory concentration: 12800 nM
Beside the measured number, compound 3's estimate is 4.3-fold (0.63 log units) below it, outside the stated range (above it).
By their numbers in this assay, from the lowest: compounds 1 and 2 (each within the scatter of the next); then compound 3.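

In this assay the exchange of 6-hydroxy-2-methylpyrimidin-4-yl for 5-chlorothiophen-2-yl on a saturated chain carbon bound to a sulfur gives a 4.1-fold higher number from compound 1 to compound 3 (0.62 log units; beyond the scatter) and so shows that, with the rest of compound 1 held fixed, the number responds to the group at this position. The step changes several things at once: a six-membered aromatic ring with 2 hetero atoms gives way to a five-membered aromatic ring with 1 hetero atom, the hydrogen-bond donor is lost, hydrogen-bond acceptors fall from 3 to 1, and a chlorine enters, so this single step cannot tie the higher number to any one of these differences. Nothing shown here accounts for the rise.

As far as these compounds go, it remains open whether the higher number goes with the chlorine or with the five-membered ring itself, a question that a plain thiophen-2-yl on the same chain carbon would address. From the compounds shown here alone, it is equally open whether a pyridin-4-yl or a group carrying an amine at this place would match compound 1 at 3100 nM or move away from it.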